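The source may report more compounds than this note shows. Statements on the series, on what has been measured and on what is new or still open speak of the compounds shown alone.

In a functional assay on RS4-11 cells (Homo sapiens) for inhibition, read by CCK-8 assay, with a stated time of 48 h (a lower number here means a stronger inhibitor, a higher number a weaker inhibitor), three analogues have been characterised so far. Compound 2 `O=S(=O)(NCCNC(=S)Nc1cc(C(F)(F)F)cc(C(F)(F)F)c1)c1ccc(-c2ccccc2Oc2ccc(O)c(O)c2)s1` gives 10300 nM. Compound 1 `O=S(=O)(NCCNC(=S)Nc1cc(C(F)(F)F)cc(C(F)(F)F)c1)c1ccc(-c2ccccc2OCc2ccccc2)s1` reaches only a limit of this assay, > 50000 nM, which is the point where one of the three values sits (the limit of > 50000 nM in this assay, at which 1 of the 3 values shown sits). The change between these two is benzyl in place of 3,4-dihydroxyphenyl on an oxygen on an aromatic ring, and the step it made was an at least 4.8-fold higher number from compound 2 to compound 1 (0.68 log units; beyond the scatter). Compound 3 `O=C(NCCNS(=O)(=O)c1ccc(-c2ccccc2Oc2ccc(O)c(O)c2)s1)Nc1cc(C(F)(F)F)cc(C(F)(F)F)c1` gives 4900 nM in this assay, the lowest of the two numbers; the difference between the cores of compound 3 and compound 2 is not broken down here. Compound 4 `O=C(NCCNS(=O)(=O)c1ccc(-c2ccccc2OCc2ccccc2)s1)Nc1cc(C(F)(F)F)cc(C(F)(F)F)c1` has not yet been tested in this assay. It differs from compound 3 by benzyl in place of 3,4-dihydroxyphenyl on an oxygen on an aromatic ring, the same change in the same place as that already seen. The account therefore expects compound 4 to sit well above compound 3 in this assay, because the matching step earlier read an at least 4.8-fold higher number from compound 2 to compound 1 (0.68 log units; beyond the scatter). Compound 4 is estimated at about 30000 nM, plausibly between 10000 nM and 50000 nM, an expected step of a 6.1-fold higher number from compound 3 to compound 4 (0.79 log units; beyond the scatter).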

Compound 4, half-maximal inhibitory concentration: > 50000 nM
Compound 4: only a limit was reported (the forecaster's own chance of this, stated with the estimate: 45%); middle value at least 1.6-fold (0.22 log units) from the limit.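

In this assay, benzyl in place of 3,4-dihydroxyphenyl on the oxygen again gives a weaker compound on the second core, with an at least 10-fold higher number from compound 3 to compound 4 (1.00 log units; beyond the scatter). Compound 4 gives > 50000 nM, which is a limit of the assay and not a number. The direction of the change therefore holds on both the core of compound 2 and the core of compound 3, but this pair of steps does not show that its size carries over from one core to the other: the same change on two cores in this assay, an at least 4.8-fold higher number (0.68 log units; beyond the scatter) from compound 2 to compound 1 and an at least 10-fold higher number (1.00 log units; beyond the scatter) from compound 3 to compound 4; the limit leaves it open whether they differ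

Going by these compounds, compound 1 and compound 4 stop at the same limit, and how far apart they lie stays open: the limit of > 50000 nM in this assay, at which 2 of the 4 values shown sit. It also stays open whether a plain phenyl or a methoxy-substituted phenyl on the same oxygen would keep the lower numbers, which would help separate the part played by the two hydroxyl groups from that of the extra carbon in benzyl.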